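This account rests on a few compounds, and the source may have more. Where it says the series, first, only, none or still open, it means among the compounds named here.

Measured so far:
compound 1 `C[C@H](O)[C@@H](CCc1cccc(F)c1)n1cnc2c(N)ncnc21` — 1.6 nM
compound 2 `C[C@H](O)[C@@H](CCc1cccc(Br)c1)n1cnc2c(N)ncnc21` — 0.6 nM
compound 3 `C[C@H](O)[C@@H](CCc1cccc(-c2nccs2)c1)n1cnc2c(N)ncnc21` — 2.6 nM

All three were tested in an assay on isolated protein for inhibition of adenosine deaminase (Bos taurus), with a stated time of 5 min; on this read-out higher numbers stand for weaker inhibition and lower numbers for stronger inhibition. Compound 3 gives the highest of the three numbers: the step of a 4.3-fold higher number from compound 2 to compound 3 (0.64 log units; beyond the scatter) lies beyond the scatter, while the step of a 1.6-fold higher number from compound 1 to compound 3 (0.21 log units; within the scatter) does not. Compound 4 `C[C@H](O)[C@@H](CCc1cccc(C(=O)O)c1)n1cnc2c(N)ncnc21` differs from compound 3 in one place: carboxy in place of 1,3-thiazol-2-yl on an aromatic carbon. Going by the values given here, the steps that bear on this are those ending at compound 3, namely a 1.6-fold higher number from compound 1 to compound 3 (0.21 log units; within the scatter) and a 4.3-fold higher number from compound 2 to compound 3 (0.64 log units; beyond the scatter), both modest at most. Among the compounds with values here, no measured step involves a carboxy group, so the expectation rests on how little the numbers have moved so far. For compound 4 a step of a 1.9-fold higher number from compound 3 to compound 4 (0.28 log units; within the scatter) is expected, roughly within the scatter. The estimate for compound 4 in this assay is 5 nM, ranging from 1.5 nM to 20 nM.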

Compound 4, inhibition constant: 53 nM
Compound 4: middle estimate off by 11-fold (1.03 log units), on the low side, and the stated range ends below it.
By their numbers in this assay, from the lowest: compound 2; then compounds 1 and 3 (each within the scatter of the next); then compound 4.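

Fluoro, bromo and 1,3-thiazol-2-yl had moved the number only modestly at this position, but carboxy brings a much larger loss of inhibition: a 20-fold higher number from compound 3 to compound 4 (1.31 log units; beyond the scatter) and a 33-fold higher number from compound 1 to compound 4 (1.52 log units; beyond the scatter) and also an 88-fold higher number from compound 2 to compound 4 (1.95 log units; beyond the scatter). All three steps are large, so this position is far from indifferent to the group it carries. Having fewer heavy atoms than 1,3-thiazol-2-yl did not spare carboxy this loss.

As far as these compounds go, whether a methyl ester, an amide or an amine at the same place would lose as much remains open. Nothing available here explains the loss.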